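This account rests on a few compounds, and the source may have more. Where it says the series, first, only, none or still open, it means among the compounds named here.

Of the compounds shown here, two have so far been measured in an assay on Sf9 cells for inhibition of Leucine-rich repeat serine/threonine-protein kinase 2 (Homo sapiens), read by TR-FRET, with stated times of 30 min and 2 h; a higher number here means a weaker inhibitor, a lower number a stronger inhibitor. Compound 1 `O=C(Nc1cccc(Cl)c1)c1cc(C(F)(F)F)ccc1OCc1ccc(F)cc1` gives 12.6 nM. Compound 2 `O=C(Nc1ccnnc1)c1cc(N2CCNCC2)ccc1OCc1ccccc1` gives 15.9 nM, the higher of the two numbers, yet the gap to compound 1 lies within the usual scatter of repeated measurements, so the two cannot be told apart on these data. Compound 3 `O=C(Nc1ccnnc1)c1cc(N2CCCC2)ccc1OCc1ccccc1` has not been measured yet. It differs from compound 2 in a single place: pyrrolidin-1-yl in place of piperazin-1-yl on an aromatic carbon. Within the data shown here, no measured pair of compounds shows this particular change, so its effect cannot be read off from anything already known and must be guessed. A modest step toward a weaker inhibitor in this assay seems plausible, though possibly not beyond the scatter. The step that this estimate means is expected to be a 1.9-fold higher number from compound 2 to compound 3 (0.28 log units; within the scatter). In this assay compound 3 is therefore estimated at 30 nM, with a likely range from 10 nM to 90 nM.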

Compound 3, half-maximal inhibitory concentration: 20 nM
Compound 3: middle estimate off by 1.5-fold (0.18 log units), on the high side; the range from low to high includes it.
By their numbers in this assay, from the lowest: compounds 1, 2 and 3 (each within the scatter of the next).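

In this assay, placing pyrrolidin-1-yl instead of piperazin-1-yl on the aromatic carbon para to the benzyloxy group gives a 1.3-fold higher number from compound 2 to compound 3 (0.10 log units; within the scatter) and so produces no readable difference. At this position, a six-membered non-aromatic ring with 2 hetero atoms and 1 hydrogen-bond donor can thus give way to a five-membered one with 1 hetero atom and 0 hydrogen-bond donors without a step beyond the scatter. No measurement at hand accounts for this outcome.

Both groups shown here are non-aromatic nitrogen rings, so this single step says little about very different groups at this carbon. Going by these compounds, whether a morpholin-4-yl group, a carboxylic acid or a simple dimethylamino group there would give a step beyond the scatter remains open.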